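Amide variation on the ring nitrogen: compound 4

The source may hold more compounds than are shown below. What is called first, only, known or untested is meant among the compounds shown, and "the series" means these compounds.

Three amides and sulfonamides on the ring nitrogen of the shared core have been measured. In a functional assay on A549 cells (Homo sapiens) for antiproliferative activity, read by MTT assay, with a stated time of 48 h (on this read-out higher numbers stand for weaker inhibition and lower numbers for stronger inhibition), compound 1 `COc1ccc(-c2cn3cc(C4=CCN(S(=O)(=O)CCc5ccccc5)CC4)ccc3n2)cc1OC` gives 7690 nM, compound 2 `COc1ccc(-c2cn3cc(C4=CCN(C(=O)C(C)(C)C)CC4)ccc3n2)cc1OC` gives 4340 nM and compound 3 `COc1ccc(-c2cn3cc(C4=CCN(C(=O)C5CC5)CC4)ccc3n2)cc1OC` gives 9140 nM. Compound 3 carries the highest number of the three: against compound 1 it is a 1.2-fold higher number from compound 1 to compound 3 (0.08 log units; within the scatter), a gap within the scatter, while against compound 2 it is a 2.1-fold higher number from compound 2 to compound 3 (0.32 log units; beyond the scatter), a modest step beyond the scatter. The other pairing, a 1.8-fold lower number from compound 1 to compound 2 (0.25 log units; within the scatter), also stays within the scatter.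

Compound 4 `COc1ccc(-c2cn3cc(C4=CCN(C(=O)c5cccc(C(F)(F)F)c5)CC4)ccc3n2)cc1OC` differs from compound 3 by 3-(trifluoromethyl)phenyl in place of cyclopropyl on a carbonyl carbon. Going by the values given here, the only step that touches the same carbonyl carbon is a 2.1-fold higher number from compound 2 to compound 3 (0.32 log units; beyond the scatter), and that swap produced only a modest change; the two swaps of the whole group on the ring nitrogen gave nothing beyond the scatter. Among the compounds with values here, no measured compound carries an aryl group on that carbonyl, so nothing points to a large move in either direction. The step is expected to be a 1.5-fold lower number from compound 3 to compound 4 (0.18 log units; within the scatter), which is not beyond the scatter. Compound 4 is therefore estimated at 6000 nM, with a range from 2500 nM to 15000 nM in this assay.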

Compound 4, half-maximal inhibitory concentration: 3690 nM
For compound 4 the middle estimate is 1.6-fold (0.21 log units) above the measured one; low and high end bracket the measured number.
By their numbers in this assay, from the lowest: compounds 4, 2, 1 and 3 (each within the scatter of the next, the first and the last beyond it).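

In this assay an aryl group on the carbonyl, with 10 heavy atoms in place of 3, does not raise the number: a 2.5-fold lower number from compound 3 to compound 4 (0.39 log units; beyond the scatter) is a modest step beyond the scatter. The 3-(trifluoromethyl)phenyl amide falls level with the tert-butyl amide, since a 1.2-fold lower number from compound 2 to compound 4 (0.07 log units; within the scatter) stays within the scatter, so two quite different groups on this carbonyl read alike and the cyclopropyl amide stands apart from both. Among swaps of the whole group on the ring nitrogen, a 2.1-fold lower number from compound 1 to compound 4 (0.32 log units; beyond the scatter) is the first to pass beyond the scatter, though it is only modest.

No evidence is available on why these groups rank as they do. Going by these compounds, whether the trifluoromethyl group matters at all stays open, as does the effect of a plain phenyl, a pyridine ring, or an amine or carboxylic acid on that aryl ring.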